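Working notes: from compound 3 to compound 4

The compounds below may be only part of what the source reports. "The series", "measured", "known", "first", "only" and "open" are said of these compounds alone.

Among the measured compounds shown here, in an ADME assay on L6 cells (Rattus norvegicus) for cytotoxicity, read by fluorescence and resazurin assay, with a stated time of 72 h (a higher number here means that more compound is needed for the effect, a lower number that less compound is needed), compound 3 (`O=c1nc(-c2ccccc2)c2cc(-c3ccccc3F)ccc2[nH]1`) gives 55800 nM, the only true number so far. Compound 1 (`Cc1cc(-c2ccc3[nH]c(=O)nc(-c4ccccc4)c3c2)ccn1`) reads > 50000 nM, which is a limit and not a number. Compound 2 (`Cc1cncc(-c2ccc3[nH]c(=O)nc(-c4ccccc4)c3c2)c1`) reads > 50000 nM, again a limit. For the measured compounds named here, the series therefore sits at the limit of > 50000 nM in this assay, at which 2 of the 3 values shown sit, with compound 3 as its single readable value.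

Compound 4 (`O=c1nc(-c2ccccc2)c2cc(-c3cncnc3)ccc2[nH]1`) carries pyrimidin-5-yl in place of 2-fluorophenyl on an aromatic carbon of the shared core: pyrimidin-5-yl in place of 2-fluorophenyl on an aromatic carbon.

Three measured steps change the group at this same place. The two that end on 2-fluorophenyl are a step that the limit leaves unreadable from compound 1 to compound 3 and a step that the limit leaves unreadable from compound 2 to compound 3. The third, which exchanges 2-methylpyridin-4-yl for 5-methylpyridin-3-yl, is a step that the two limits leave unreadable from compound 1 to compound 2. None of them has a readable size, so they give no size or direction to carry over. No change beyond the scatter is therefore expected in this assay, and the expected result stays close to the value of compound 3 at 55800 nM. The estimated move is a 1.0-fold higher number from compound 3 to compound 4 (0.02 log units; within the scatter). Compound 4 is expected at about 58000 nM, within an estimated range of 30000 nM to 110000 nM, and a report as a limit is the likelier outcome.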

Compound 4, half-maximal effective concentration: > 50000 nM
Compound 4: a limit, no number (the forecaster's own chance of this, stated with the estimate: 75%); the middle value is on the limit's open side.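

None of the steps from compound 1, compound 2 or compound 3 to compound 4 can be read, because the series rests on a limit: the limit of > 50000 nM in this assay, at which 3 of the 4 values shown sit.

The compounds shown leave open whether changing the group at this place moves the read-out in this assay at all, and how far compound 1, compound 2 and compound 4 lie from compound 3 at 55800 nM.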